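The source may report more compounds than this note shows. Statements on the series, on what has been measured and on what is new or still open speak of the compounds shown alone.

In an ADME assay on HEK293 cells (Homo sapiens) for cytotoxicity, read by resazurin assay, with a stated time of 48 h (on this read-out higher numbers stand for lower toxicity in this test and lower numbers for higher toxicity in this test), compound 1 `O=S(=O)(Nc1ccc(-c2nc3ccccc3o2)cc1)c1cccc(F)c1` gives > 100000 nM, which is a limit of the assay rather than a number. Compound 2 `O=S(=O)(Nc1ccc(-c2nc3ccccc3o2)cc1)c1ccc(O)cc1` gives > 100000 nM, likewise a limit. The step that the two limits leave unreadable from compound 1 to compound 2 therefore has no readable size, and compound 2 stands at the limit of > 100000 nM in this assay, at which 2 of the 2 values shown sit. Compound 3 `COc1ccc(Cl)cc1S(=O)(=O)Nc1ccc(-c2nc3ccccc3o2)cc1` differs from compound 2 by 5-chloro-2-methoxyphenyl in place of 4-hydroxyphenyl on a sulfonyl sulfur. Within the data shown here, no measured step bears a readable size on this change, so no shift beyond the scatter is expected. Compound 3 is therefore expected to give about 100000 nM, between 30000 nM and 300000 nM, most probably again as a limit. The expected step is a number no higher from compound 2 to compound 3 (the limit leaves the size open).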

Compound 3, half-maximal cytotoxic concentration: 75000 nM
Compound 3: middle estimate off by 1.3-fold (0.12 log units), on the high side, and the stated range covers the measured number.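

In this assay, among these compounds, compound 3 gives the first value with this kind of group on the sulfonyl sulfur that is a number and not a limit. The change reads as an at least 1.3-fold lower number from compound 2 to compound 3 (0.12 log units; that floor lies within the scatter), and as an at least 1.3-fold lower number from compound 1 to compound 3 (0.12 log units; that floor lies within the scatter), so neither floor shows a shift beyond the scatter. The step between the two earlier compounds cannot be read.

On these data alone, the true size of both new steps stays open, as the other values shown are limits: the limit of > 100000 nM in this assay, at which 2 of the 3 values shown sit. Also open, as far as these compounds go, is whether a ring carrying an amine or a carboxylic acid at this place would give a number or a limit.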